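Swapping Methylamino for Methoxy on a Carbonyl Carbon

The source may report more compounds than this note shows. Statements on the series, on what has been measured and on what is new or still open speak of the compounds shown alone.

- Compound 1 `CNC(=O)C1=C[C@@H]2[C@@H](C(C)C)CC[C@@]3(CO3)[C@H]2C(=O)OC1` gives 1280 nM
- Compound 2 `CNC(=O)C1=C[C@@H]2[C@@H](C(C)C)CC[C@@](O)(CO)[C@H]2C(=O)OC1` gives > 32000 nM

Among the measured compounds shown here, in a functional assay on NAMALVA cells (Homo sapiens) for inhibition, with a stated time of 72 h (a higher number here means a weaker inhibitor, a lower number a stronger inhibitor), compound 1 gives 1280 nM as the only exact number so far. Compound 2 reads > 32000 nM and this is a limit of the assay, not a number. Compound 3 `COC(=O)C1=C[C@@H]2[C@@H](C(C)C)CC[C@@]3(CO3)[C@H]2C(=O)OC1` keeps the core of compound 1 but has methoxy in place of methylamino on a carbonyl carbon. For the measured compounds named here, no measured step shows what this swap does, so only a modest, uncertain gain in strength is expected in this assay. The expected change is a 1.8-fold lower number from compound 1 to compound 3 (0.26 log units; within the scatter) as an estimate. Compound 3 is estimated at 700 nM with a range from 130 nM to 3500 nM.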

Compound 3, half-maximal inhibitory concentration: 1740 nM
Compound 3: the middle estimate sits 2.5-fold (0.40 log units) below what was measured, within the range that was stated.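

With methoxy in place of methylamino on a carbonyl carbon, this assay shows a 1.4-fold higher number from compound 1 to compound 3 (0.13 log units; within the scatter) and the two compounds cannot be told apart. At this position, then, the hydrogen-bond donor counted for methylamino can go, and a hydrogen-bond acceptor can enter, with no readable difference in strength. Nothing measured here gives a reason for this result.

The compounds shown leave open what a carboxylic acid, a plain amino group or a longer chain such as ethoxy would do on this carbonyl carbon.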